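Trifluoromethyl in Place of Hydroxy on the Aryl Ring

The source may report more compounds than this note shows. Statements on the series, on what has been measured and on what is new or still open speak of the compounds shown alone.

Three measured compounds share one core and differ only in the aromatic ring attached to its nitrogen. In an assay on CHO-K1 cells for displacement of a labelled ligand from adenosine receptor A1 (Homo sapiens), tested at 50 uM (a higher number here means more inhibition at the concentration tested (going by the name of the read-out), a lower number less inhibition), compound 1 `CCOC(=O)c1nn(-c2ccc(C(C)(C)C)cc2)c(=O)c2c(N)scc12` gives 23%. Compound 2 `CCOC(=O)c1nn(-c2cccc(Cl)c2)c(=O)c2c(N)scc12` gives 100% in this assay, and compound 3 `CCOC(=O)c1nn(-c2ccc(O)cc2)c(=O)c2c(N)scc12` gives 65.8%. Compound 3 therefore sits second highest of the three: the step of a number 34.2 percentage points lower from compound 2 to compound 3 (beyond the scatter) is a large fall, while the step of a number 42.8 percentage points higher from compound 1 to compound 3 (beyond the scatter) is a large rise, both beyond the scatter.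

Compound 4 `CCOC(=O)c1nn(-c2ccc(C(F)(F)F)cc2)c(=O)c2c(N)scc12` is the next step: trifluoromethyl in place of hydroxy on an aromatic carbon. The step from compound 1 to compound 3 bears most directly on it, since it changed the same aromatic carbon and produced a large rise when hydroxy replaced tert-butyl. The incoming trifluoromethyl, like tert-butyl, brings no hydrogen-bond donor and no hydrogen-bond acceptor, so a move back toward compound 1 is expected. The step from compound 2 to compound 3 concerns a different group on a different ring position and gives less guidance. A sizeable downward step a number 25.8 percentage points lower from compound 3 to compound 4 (beyond the scatter) in this assay is therefore expected. Compound 4 is estimated at 40%, within 10% to 75%.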

Compound 4, a percentage reported as inhibition, at one concentration (the size of the read-out at that concentration, not a potency): 77.2%
Beside the measured number, compound 4's estimate is 37.2 percentage points below it; the measured number lies above the stated range.
By their numbers in this assay, from the lowest: compound 1; then compound 3; then compound 4; then compound 2.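

The step of a number 11.4 percentage points higher from compound 3 to compound 4 (beyond the scatter) is modest, but its direction is the new information: in this assay, removing hydroxy from this aromatic carbon does not by itself lower the number, since trifluoromethyl enters with no hydrogen-bond donor and no hydrogen-bond acceptor. The step of a number 54.2 percentage points higher from compound 1 to compound 4 (beyond the scatter) is large, even though tert-butyl and trifluoromethyl both lack a hydrogen-bond donor and acceptor, so counting these features does not put the three compounds with a group on this carbon in order. The compounds shown offer no measurement that explains either step.

As far as these compounds go, what an amine, a carboxylic acid or a methoxy group would give on this same aromatic carbon remains open, so three groups provide only a first sketch of how this position responds to change. Also open is how trifluoromethyl would read at the ring position that carries the chloro group in compound 2, since no compound shown pairs that position with that group.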